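The compounds below may be only part of what the source reports. "The series", "measured", "known", "first", "only" and "open" are said of these compounds alone.

Compound 1 `O=C1O[C@@H](CN2CCC(O)CC2)CN1c1ccc(-n2cc(-c3ccccn3)cn2)c(F)c1` gives 1.63 in a physicochemical assay for lipophilicity, read by HPLC, measured as octanol-water partition; on this read-out higher numbers stand for higher lipophilicity and lower numbers for lower lipophilicity.
Compound 2 `O=C1CCC(=O)N1C[C@H]1CN(c2ccc(-n3cc(-c4ccccn4)cn3)c(F)c2)C(=O)O1` gives 1.58 in this assay.
Compound 3 `O=C1CSC(=O)N1C[C@H]1CN(c2ccc(-n3cc(-c4ccccn4)cn3)c(F)c2)C(=O)O1` gives 2.18 in this assay.

All three compounds share one core and differ only in the group that sits on a saturated chain carbon bound to a saturated ring carbon. On these numbers compound 3 stands highest of the three: the step of a number 0.55 log units higher from compound 1 to compound 3 (beyond the scatter) and the step of a number 0.60 log units higher from compound 2 to compound 3 (beyond the scatter) both lie beyond the scatter, while the step of a number 0.05 log units lower from compound 1 to compound 2 (within the scatter) lies within it, so compound 1 and compound 2 cannot be told apart here.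

Compound 4 `CC(=O)OC[C@H]1CN(c2ccc(-n3cc(-c4ccccn4)cn3)c(F)c2)C(=O)O1` has not yet been measured in this assay. The change from compound 3 to compound 4 is acetoxy in place of 2,4-dioxo-1,3-thiazolidin-3-yl on a saturated chain carbon bound to a saturated ring carbon. Among the compounds with values here, no measured step involves acetoxy, so the only guide is that the two steps leading into compound 3 were each modest rises beyond the scatter, and the group that produced them now leaves. The group that enters has no ring and fewer heavy atoms, so a step downward in this assay of roughly the size of the scatter, rather than a full reversal, is expected. Compound 4 is therefore estimated at 1.9, with a range from 1.5 to 2.3. The expected step is a number 0.28 log units lower from compound 3 to compound 4 (within the scatter).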

Compound 4, partition coefficient: 2.09
For compound 4 the middle estimate is 0.19 log units below the measured one; the range from low to high includes it.
By their numbers in this assay, from the lowest: compounds 2 and 1 (each within the scatter of the next); then compounds 4 and 3 (each within the scatter of the next).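

With a number 0.09 log units lower from compound 3 to compound 4 (within the scatter) in this assay, the two compounds cannot be told apart, even though acetoxy has 4 heavy atoms and no ring while 2,4-dioxo-1,3-thiazolidin-3-yl has 7 heavy atoms and a five-membered ring. Acetoxy also stands clear of the other two groups on a saturated chain carbon bound to a saturated ring carbon, with a number 0.51 log units higher from compound 2 to compound 4 (beyond the scatter) and a number 0.46 log units higher from compound 1 to compound 4 (beyond the scatter) as the two steps that show it, so among these four compounds the upper pair holds one group with a ring and one without, and a ring at this place does not by itself decide the reading. Nothing measured here explains why acetoxy and 2,4-dioxo-1,3-thiazolidin-3-yl read alike.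

On these data alone, it remains open whether a longer ester such as propanoyloxy, or an acetamido group with nitrogen in place of the ester oxygen, would stay with compound 3 and compound 4 or fall nearer compound 1 and compound 2. A carboxylic acid or a simple amine at this place is also an open case, since the four groups shown carry no net charge and give no guide to how either would read.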